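This account rests on a few compounds, and the source may have more. Where it says the series, first, only, none or still open, it means among the compounds named here.

Measured compounds:
Compound 1 `CCc1ccc(NC2=CC(=O)c3c(nc4n3[C@H]3OC[C@@H](O)[C@H]3OC4)C2=O)cc1` — 1110 nM
Compound 2 `O=C1C=C(Nc2cccc(F)c2)C(=O)c2c1nc1n2[C@H]2OC[C@@H](O)[C@H]2OC1` — 2180 nM
Compound 3 `CCOc1ccccc1NC1=CC(=O)c2nc3n(c2C1=O)[C@H]1OC[C@@H](O)[C@H]1OC3` — 2450 nM

All three share one core and differ only in the group on the amine nitrogen. In a functional assay on MGC-803 cells (Homo sapiens) for inhibition, read by sulforhodamine B assay (on this read-out higher numbers stand for weaker inhibition and lower numbers for stronger inhibition), compound 1 gives the lowest of the three numbers; compound 2 sits within the scatter of it, compound 3 just beyond. For the measured compounds named here, the one counted step, a 1.1-fold higher number from compound 2 to compound 3 (0.05 log units; within the scatter), lies within the scatter. Compound 4 `O=C1C(Nc2cccc(Cl)c2)=CC(=O)c2c1nc1n2[C@H]2OC[C@@H](O)[C@H]2OC1` is not yet measured; against compound 1 it shows (3-chlorophenyl in place of 4-ethylphenyl on an amine nitrogen). Going by the values given here, no measured step covers this change. Compound 2 carries the nearest group, 3-fluorophenyl, and its value 2180 nM together with the flat step to compound 3 points to a modest rise at most. The expected step is a 1.5-fold higher number from compound 1 to compound 4 (0.19 log units; within the scatter). For compound 4 the estimate is 1700 nM, with a range from 800 nM to 3600 nM.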

Compound 4, half-maximal inhibitory concentration: 1530 nM
Estimate against measurement, compound 4: 1.1-fold (0.05 log units) above; the range from low to high includes it.
By their numbers in this assay, from the lowest: compounds 1, 4, 2 and 3 (each within the scatter of the next, the first and the last beyond it).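

In this assay, putting 3-chlorophenyl in place of 4-ethylphenyl on the amine nitrogen gives a 1.4-fold higher number from compound 1 to compound 4 (0.14 log units; within the scatter), so this exchange of one substituted phenyl for another, with a different substituent at a different ring position, stays within the scatter. The two groups therefore cannot be told apart on this read-out. Nothing at hand accounts for the size of this step.

All compounds shown carry a substituted phenyl on this nitrogen. As far as these compounds go, how a carboxylic acid or a basic amine on that ring would read, or a plain alkyl chain in its place, remains open.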